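Methyl branching at the chain and solubility in a quinone series

A few compounds are considered here, and "the series" means these few. Any claim that something is new, unique, unknown or untested is made for them only; others in the source may bear on it.

Measured compounds:
Compound 1, `O=C(CCCCCNc1c(Nc2ccccc2)c(=O)c1=O)NO`, in a physicochemical assay for solubility, with a stated time of 24 h, tested at 30 mg/mL (on this read-out lower numbers stand for lower solubility and higher numbers for higher solubility), gives 2200000 nM.
Compound 2, `C[C@H](Nc1c(NCCCCCC(=O)NO)c(=O)c1=O)c1ccccc1`, in this assay gives 28000000 nM.
Compound 3, `CC[C@H](Nc1c(NCCCCCC(=O)NO)c(=O)c1=O)c1ccccc1`, in this assay gives 57000000 nM.

Compound 1 stands lowest of the three in this assay; the step of a 13-fold higher number from compound 1 to compound 2 (1.10 log units; beyond the scatter) is large, and its structural basis is phenyl in place of 1-phenylethyl on a nitrogen on an aromatic ring. Within the core of compound 2, the step of a 2.0-fold higher number from compound 2 to compound 3 (0.31 log units; beyond the scatter) is modest and comes from methyl in place of hydrogen on a saturated chain carbon, two bonds along the chain from an aromatic carbon and a nitrogen on an aromatic ring.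

Compound 4, `CC(CCCCC(=O)NO)Nc1c(Nc2ccccc2)c(=O)c1=O`, is not yet measured in this assay. It differs from compound 1 by methyl in place of hydrogen on a saturated chain carbon bound to a nitrogen on an aromatic ring and a saturated chain carbon. This is the same kind of change as that from compound 2 to compound 3, although the place differs: in compound 3 the methyl enters on a saturated chain carbon two bonds along the chain from an aromatic carbon and a nitrogen on an aromatic ring, whereas in compound 4 it enters on a saturated chain carbon bound to a nitrogen on an aromatic ring and a saturated chain carbon. Among the measured compounds shown here, since the only comparable step is a 2.0-fold higher number from compound 2 to compound 3 (0.31 log units; beyond the scatter), a step of about the same modest size is expected for compound 4, a 1.8-fold higher number from compound 1 to compound 4 (0.26 log units; within the scatter), because compound 1 starts from 2200000 nM. Compound 4 is therefore estimated at 4000000 nM, expected to lie between 2000000 nM and 9000000 nM.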

Compound 4, solubility: 46000000 nM
The estimate for compound 4 lay 12-fold (1.06 log units) below the measured number, outside the stated range (above it).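

In this assay, methyl in place of hydrogen on a saturated chain carbon bound to a nitrogen on an aromatic ring and a saturated chain carbon gives a 21-fold higher number from compound 1 to compound 4 (1.32 log units; beyond the scatter), while the same kind of change at a different place and on a different core gives a 2.0-fold higher number from compound 2 to compound 3 (0.31 log units; beyond the scatter). The direction of the change therefore carried over in this one pair of steps, but its size did not, and with both the core and the place differing, the data cannot show which of the two matters. Nothing shown explains why one step is large and the other modest.

The compounds shown leave open what methyl would give on the matching saturated chain carbon of the core of compound 2, which would separate the role of the core from that of the place. They also leave open what an ethyl group or an amine would give in place of that methyl on the core of compound 1.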